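Oxazole ketones: methoxy in place of trifluoromethyl ketone

The source may hold more compounds than are shown below. What is called first, only, known or untested is meant among the compounds shown, and "the series" means these compounds.

Working notes on the series. In an assay on HEK-293T cells for inhibition of diacylglycerol lipase-alpha (Homo sapiens), read by colorimetric assay (on this read-out lower numbers stand for stronger inhibition and higher numbers for weaker inhibition), compound 1 `O=C(CCCCCCc1ccccc1)c1ncc(Cl)o1` returns only a limit of the assay, > 10000 nM. Compound 2 `CSc1cnc(C(=O)CCCCCCc2ccccc2)o1` likewise returns only a limit in this assay, > 10000 nM. The change a step that the two limits leave unreadable from compound 1 to compound 2 therefore cannot be read, both ends sitting at the limit. Compound 3 `O=C(CCCCCCc1ccccc1)c1ncc(-c2ccc(C(=O)C(F)(F)F)cc2)o1` also gives only a limit in this assay, > 10000 nM. Compound 3 thus stands exactly where every measured value of the series stands, namely at the limit of > 10000 nM in this assay, at which 3 of the 3 values shown sit, and no measured number places it higher or lower than the other two.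

Compound 4 `COc1ccc(-c2cnc(C(=O)CCCCCCc3ccccc3)o2)cc1` differs from compound 3 by methoxy in place of (trifluoromethyl)carbonyl on an aromatic carbon. Among the compounds with values here, no measured step bears on this change: the single one-place step recorded is unreadable, and the group that enters, a methoxy, has no counterpart anywhere among the measured compounds. Within the data shown here, the measured values therefore give no direction and no size for the step, and the expectation rests on the fact that compound 3 sits at the limit.

For compound 4 the estimated value in this assay is 20000 nM, with a range from 5000 nM to 100000 nM. The expected step that the limit leaves unreadable from compound 3 to compound 4 is taken as none beyond the scatter, and the most likely outcome is again a limit rather than a number.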

Compound 4, half-maximal inhibitory concentration: > 10000 nM
Compound 4: no number, only a limit; the forecaster's own chance of this, stated with the estimate: 85%; the middle value is on the limit's open side.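

Compound 4 gives only a limit, so the steps to it from compound 1, compound 2 and compound 3 cannot be read, and the series offers no comparison: the limit of > 10000 nM in this assay, at which 4 of the 4 values shown sit. The compounds shown leave open which group on the shared core, if any, would give a readable inhibition value, and how large any difference between these groups would be.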